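A Methyl Group Added to a Phenol: What to Expect

This account rests on a few compounds, and the source may have more. Where it says the series, first, only, none or still open, it means among the compounds named here.

Of the compounds shown here, two have so far been measured in a functional assay on M14 cells (Homo sapiens) for inhibition, read by sulforhodamine B assay, with a stated time of 48 h, tested at 10 uM; on this read-out lower numbers stand for a stronger effect and higher numbers for a weaker effect at the one concentration tested. Compound 1 `COc1cc(Cl)cc(-c2nn(-c3cccc(NC(=O)c4cccc(C(F)(F)F)c4)c3)cc2-c2ccncc2)c1` gives 56.3% in this assay. Compound 2 `O=C(Nc1cccc(-n2cc(-c3ccncc3)c(-c3cc(O)cc(Cl)c3)n2)c1)c1cc(C(F)(F)F)cc(C(F)(F)F)c1` gives 24.5% in this assay, the lower of the two numbers, with compound 1 standing a number higher that lies beyond the scatter. Compound 1 and compound 2 differ from each other in more than one place, so no single step can be read between them.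

Compound 3 `COc1cc(Cl)cc(-c2nn(-c3cccc(NC(=O)c4cc(C(F)(F)F)cc(C(F)(F)F)c4)c3)cc2-c2ccncc2)c1` has not yet been measured in this assay. It differs from compound 2 in one place: methyl in place of hydrogen on an oxygen on an aromatic ring. Within the data shown here, no measured pair isolates this change, so its size and direction are not known from the data. In this assay compound 3 is expected to give about 35%, within a range from 15% to 60%. The step of a number 10.5 percentage points higher from compound 2 to compound 3 (beyond the scatter) is accordingly expected to be small to moderate, toward a higher number, and may well fall within the scatter.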

Compound 3, a percentage reported as activity, at one concentration (the size of the read-out at that concentration, not a potency): 67.3%
The estimate for compound 3 lay 32.3 percentage points below the measured number; the whole stated range lies below it.
By their numbers in this assay, from the lowest: compound 2; then compound 1; then compound 3.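

In this assay, the change from 3-chloro-5-hydroxyphenyl to 3-chloro-5-methoxyphenyl can now be read on its own, and the step is large (a number 42.8 percentage points higher from compound 2 to compound 3 (beyond the scatter)), so at this position methyl on the oxygen comes with a much weaker effect at the one concentration tested. The second step, trifluoromethyl in place of hydrogen on an aromatic carbon, is modest and also points toward a weaker effect (a number 11 percentage points higher from compound 1 to compound 3 (beyond the scatter)), so with methoxy in place this added trifluoromethyl does not bring the number down. No measurement here explains either step. The compounds shown leave open whether an amine or a longer chain such as ethoxy in place of hydroxy would behave like hydroxy or like methoxy. They also leave open how large the hydroxy to methoxy step is when only one trifluoromethyl is present.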